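This account rests on a few compounds, and the source may have more. Where it says the series, first, only, none or still open, it means among the compounds named here.

The study set out three compounds in an in vitro assay on HEK293 cells for displacement of a labelled ligand from adenosine receptor A2b (Homo sapiens); on this read-out higher numbers stand for weaker inhibition and lower numbers for stronger inhibition. Compound 1, `CCCn1c(=O)c2nc(-c3cnn(-c4ccccc4)c3C(F)(F)F)[nH]c2n(CCC)c1=O`, gives a result in this assay that is a limit of the assay rather than a number, > 6600 nM. Compound 3, `CCCn1c(=O)c2c(nc(-n3cccn3)n2Cc2ccccc2)n(CCC)c1=O`, likewise gives only a limit in this assay, > 5800 nM. Within the data shown here, compound 2, `CCCn1c(=O)c2nc(-c3cnn(Cc4ccccc4C(F)(F)F)c3)[nH]c2n(CCC)c1=O`, is the one compound with a measured number in this assay, 37 nM, so it stands alone as the single fixed point. The results of compound 1 and compound 3 sit at the limit of > 6600 nM in this assay, at which 1 of the 3 values shown sits, and (the limit of > 5800 nM in this assay, at which 1 of the 3 values shown sits).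

Compound 4, `CCCn1c(=O)c2nc(-c3cnn(Cc4ccccc4OC)c3)[nH]c2n(CCC)c1=O`, has not yet been measured. It differs from compound 2 in one place: methoxy in place of trifluoromethyl on an aromatic carbon, ortho to a large group, which reads as 2-(trifluoromethyl)benzyl going to 2-methoxybenzyl. Among the measured compounds shown here, no measured step between two compounds in this assay covers a change of this kind, so there is nothing to set its size against. Compound 4 is expected to stay close to compound 2, with a step in this assay estimated at a 1.6-fold higher number from compound 2 to compound 4 (0.21 log units; within the scatter), a shift of modest size that may well lie within the scatter. The inhibition constant of compound 4 in this assay is estimated at 60 nM, within a range of 15 nM to 250 nM.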

Compound 4, inhibition constant: 37 nM
Estimate against measurement, compound 4: 1.6-fold (0.21 log units) above; the range from low to high includes it.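

In this assay, methoxy in place of trifluoromethyl on an aromatic carbon, ortho to a large group, brings no change at the digits printed from compound 2 to compound 4 (within the scatter). Among these compounds, this is the first step that can be read at this position: the earlier compounds held no pair differing in one place, and now 2-methoxybenzyl is seen to stand in for 2-(trifluoromethyl)benzyl with the result held within the scatter. Nothing in the data shown bears on why the two groups read alike.

On these data alone, whether an amine or a carboxylic acid on this same aromatic carbon would also leave the inhibition constant within the scatter of these two compounds stays open. So does whether the result would hold if a longer chain, such as ethoxy, took the place of methoxy.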